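From morpholin-4-yl to cyclopentylamino on the sulfonyl sulfur

This account rests on a few compounds, and the source may have more. Where it says the series, first, only, none or still open, it means among the compounds named here.

In an ADME assay on a cell-free system (plasma, Mus musculus) for metabolic stability, tested at 5 uM (on this read-out higher numbers stand for a longer-lived compound and lower numbers for a shorter-lived compound), compound 1 (`O=C(O)c1ccc(NCCCCCCCC(F)(F)F)c(S(=O)(=O)N2CCCC2)c1`) gives > 2 h and this is a limit of the assay, not a number. Compound 2 (`O=C(O)c1ccc(NCCCCCCCC(F)(F)F)c(S(=O)(=O)N2CCOCC2)c1`) gives > 2 h in this assay and this too is a limit, not a number. All that can be said of where compound 2 stands rests on the limit of > 2 h in this assay, at which 2 of the 2 values shown sit, and no finer placing is possible.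

Compound 3 (`O=C(O)c1ccc(NCCCCCCCC(F)(F)F)c(S(=O)(=O)NC2CCCC2)c1`) carries cyclopentylamino in place of morpholin-4-yl on a sulfonyl sulfur. Among the compounds with values here, neither compound 1 nor compound 2 has a cyclopentylamino group, so no measured step covers this kind of change. Within the data shown here, the only measured step is a step that the two limits leave unreadable from compound 1 to compound 2 and it offers no size to carry over. On that step, no change beyond the scatter is expected in this assay in either direction.

The estimated move is a step that the limit leaves unreadable from compound 2 to compound 3 and it remains only an expectation. Compound 3 is expected at 3 h (estimated range 1.5 h to 6 h) and a report as a limit once more would be no surprise.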

Compound 3, half-life: > 2 h
Compound 3 ended at the assay's limit; the forecaster's own chance of this, stated with the estimate: 80%; the middle value lies beyond the limit too.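

In this assay compound 3 gives > 2 h, which is a limit and not a number. No step among compound 1, compound 2 and compound 3 can be read, as all rest on one limit: the limit of > 2 h in this assay, at which 3 of the 3 values shown sit.

The compounds shown leave open whether pyrrolidin-1-yl, morpholin-4-yl and cyclopentylamino on a sulfonyl sulfur differ at all in this assay.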